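Chloro to fluoro on the shared core

The source may hold more compounds than are shown below. What is called first, only, known or untested is meant among the compounds shown, and "the series" means these compounds.

In a functional assay on MDA-MB-435 cells (Homo sapiens) for inhibition, read by sulforhodamine B assay (a higher number here means a weaker inhibitor of growth, a lower number a stronger inhibitor of growth), compound 1 (`N#CC1=C(N)OC2=C(C(=O)c3ccccc32)C12C(=O)Nc1ccc(Br)cc12`) gives 1800 nM. Compound 2 (`N#CC1=C(N)OC2=C(C(=O)c3ccccc32)C12C(=O)Nc1ccc(Cl)cc12`) gives 2100 nM, so the two values lie within the scatter of each other. Compound 3 (`N#CC1=C(N)OC2=C(C(=O)c3ccccc32)C12C(=O)Nc1ccc(F)cc12`) has fluoro in place of chloro on an aromatic carbon. Among the compounds with values here, one measured step bears on this change, the exchange of bromo for chloro at the same place, a 1.2-fold higher number from compound 1 to compound 2 (0.07 log units; within the scatter), which is within the scatter. No step beyond the scatter is therefore expected in this assay. Compound 3 is expected at 2300 nM, with an estimated range of 1100 nM to 5000 nM.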

Compound 3, concentration for 50% growth inhibition: > 100000 nM
Compound 3 gave a limit, no number; the forecaster's own chance of this, stated with the estimate: 3%; middle value at least 43-fold (1.63 log units) from the limit.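

At this aromatic carbon the halogens are not interchangeable in this assay: fluoro in place of chloro gives an at least 47-fold higher number from compound 2 to compound 3 (1.67 log units; beyond the scatter), and fluoro in place of bromo gives an at least 55-fold higher number from compound 1 to compound 3 (1.74 log units; beyond the scatter). The bromo and chloro pair alone, within the scatter of each other, did not reveal this sharp break. Compound 3 gives a limit of the assay, not a number: the limit of > 100000 nM in this assay, at which 1 of the 3 values shown sits.

Still open, on these data alone, is how far compound 3 lies past that limit. Also open, as far as these compounds go, is whether the break belongs to fluoro alone, or whether a methyl, a methoxy or a bare hydrogen at this carbon would track chloro and bromo instead.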